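From 2-chlorophenyl to 3-chlorophenyl on a carbonyl carbon

The compounds below may be only part of what the source reports. "The series", "measured", "known", "first", "only" and "open" are said of these compounds alone.

Measured in a functional assay on NCI-H23 cells (Homo sapiens) for cytotoxicity, read by sulforhodamine B assay, with a stated time of 72 h; on this read-out lower numbers stand for stronger inhibition of growth and higher numbers for weaker inhibition of growth:
compound 1 `O=C(Nc1cc(C(F)(F)F)cc(C(F)(F)F)c1)C1CCc2ccccc2N1C(=O)c1ccccc1Cl`: 2080 nM
compound 2 `CCCCCCCCC(=O)N1c2ccccc2CCC1C(=O)Nc1ccccc1C(F)(F)F`: 4220 nM
compound 3 `O=C(Nc1ccccc1C(F)(F)F)C1CCc2ccccc2N1`: 56800 nM

Among these three, compound 1 has the lowest number, at 2080 nM. Compound 2 follows at 4220 nM, and compound 3 lies far higher at 56800 nM.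

The unmeasured compound 4 `O=C(Nc1cc(C(F)(F)F)cc(C(F)(F)F)c1)C1CCc2ccccc2N1C(=O)c1cccc(Cl)c1` differs from compound 1 in a single place: 3-chlorophenyl in place of 2-chlorophenyl on a carbonyl carbon. In words, 3-chlorophenyl stands in place of 2-chlorophenyl on a carbonyl carbon.

For the measured compounds named here, only one measured step is available, and it bears on this change only loosely. That step, a 13-fold higher number from compound 2 to compound 3 (1.13 log units; beyond the scatter), is large, but it replaces octylcarbonyl with hydrogen and so removes the whole group. Going by the values given here, no measured pair compares two placements of the chlorine, so the data give no direction for the change. A small step is expected, with no clear move beyond the scatter.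

The expected change is a 1.1-fold higher number from compound 1 to compound 4 (0.04 log units; within the scatter). Compound 4 is estimated at 2300 nM, with an expected range of 1000 nM to 5500 nM.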

Compound 4, concentration for 50% growth inhibition: 420 nM
For compound 4 the middle estimate is 5.5-fold (0.74 log units) above the measured one; measured number below the stated range.
By their numbers in this assay, from the lowest: compound 4; then compound 1; then compound 2; then compound 3.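

In this assay, the exchange of 2-chlorophenyl for 3-chlorophenyl on the carbonyl carbon gives a 5.0-fold lower number from compound 1 to compound 4 (0.69 log units; beyond the scatter), so these two groups are not interchangeable here, although they have the same atoms and the same ring. The earlier step, a 13-fold higher number from compound 2 to compound 3 (1.13 log units; beyond the scatter), showed only what happens when a whole group on the ring nitrogen gives way to hydrogen, whereas this pair shows that the number also responds to a change within the group, with the rest of the structure kept. No measurement at hand offers an explanation for this step.

The compounds shown leave open whether bromophenyl, methoxyphenyl or unsubstituted phenyl would give a lower or higher number on this carbonyl carbon. They also leave open whether the same exchange would give a step of similar size with the amide part of compound 2.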